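The compounds below may be only part of what the source reports. "The series", "measured", "known", "first", "only" and "open" are said of these compounds alone.

Measured compounds:
compound 1 `O=[N+]([O-])c1cccc(CSc2ncnc3c2ncn3[C@@H]2O[C@H](CO)[C@@H](O)[C@H]2O)c1`, 1.78 nM
compound 2 `CC(C)(C)c1ccc(CSc2ncnc3c2ncn3[C@@H]2O[C@H](CO)[C@@H](O)[C@H]2O)cc1`, 10000 nM

Both were tested in an assay on isolated protein for inhibition of Equilibrative nucleoside transporter 1 (Homo sapiens); on this read-out higher numbers stand for weaker inhibition and lower numbers for stronger inhibition. Compound 2 holds the highest of the two numbers; its nearest neighbour is compound 1, and the step of a 5600-fold higher number from compound 1 to compound 2 (3.75 log units; beyond the scatter) separates them. Compound 3 `OC[C@H]1O[C@@H](n2cnc3c(SCc4ccc(Cl)c(Cl)c4)ncnc32)[C@H](O)[C@@H]1O` has not yet been measured in this assay. It differs from compound 2 in one place: 3,4-dichlorophenyl in place of 4-(tert-butyl)phenyl on a saturated chain carbon bound to a sulfur. Going by the values given here, the only measured step that bears on this change is a 5600-fold higher number from compound 1 to compound 2 (3.75 log units; beyond the scatter), which shows that exchanging the aryl group on the saturated chain carbon bound to a sulfur can move the number a great deal. Among the compounds with values here, compound 3 carries a group that neither measured compound has, so the single step fixes no value for it; it shows only that this place matters strongly. A step toward lower numbers is therefore expected, a 100-fold lower number from compound 2 to compound 3 (2.00 log units; beyond the scatter). For compound 3 the estimate in this assay is 100 nM, within 10 nM to 2000 nM.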

Compound 3, inhibition constant: 12.6 nM
The estimate for compound 3 lay 7.9-fold (0.90 log units) above the measured number; low and high end bracket the measured number.
By their numbers in this assay, from the lowest: compound 1; then compound 3; then compound 2.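

In this assay, the change to 3,4-dichlorophenyl gives a 790-fold lower number from compound 2 to compound 3 (2.90 log units; beyond the scatter), so the very high number of compound 2 does not hold for every substituted phenyl on the saturated chain carbon bound to a sulfur. Going by these compounds alone, the 3-nitrophenyl group is not the only one that keeps the number low, yet the exchange for it still gives a 7.1-fold higher number from compound 1 to compound 3 (0.85 log units; beyond the scatter), a modest step but one beyond the scatter, so the two groups are not interchangeable here. Nothing available accounts for these differences.

With only three aryl groups shown, it remains open whether the 4-(tert-butyl)phenyl group stands alone in giving such a high number or whether other groups on this carbon would do the same. Also open, as far as these compounds go, is how an unsubstituted phenyl, a phenyl carrying an amine or a carboxylic acid, or a longer chain between the sulfur and the ring would compare.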